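The compounds below may be only part of what the source reports. "The series", "measured", "known", "first", "only" and "open" are said of these compounds alone.

Within the data shown here, compound 2 `Cc1ccc(OCC(=O)N(Cc2cccs2)C2COC2)cc1` holds the lower of the two numbers measured so far in an assay on HEK293 cells for agonist activity at transient receptor potential cation channel subfamily M member 8 (Homo sapiens), read by fluorescence and calcium flux, with a stated time of 15 min (on this read-out lower numbers stand for an effect already at smaller amounts and higher numbers for an effect only at larger amounts of compound), where compound 2 gives 23000 nM. Among the measured compounds shown here, its only measured neighbour is compound 1 `Cc1ccc(OCC(=O)N(Cc2cccs2)c2cnn(C)c2)cc1`, which in this assay gives 63000 nM. For the measured compounds named here, the one measured step between them, a 2.7-fold lower number from compound 1 to compound 2 (0.44 log units; beyond the scatter), shows that replacing 1-methyl-1H-pyrazol-4-yl with oxetan-3-yl on the amide-type nitrogen brought a modest improvement.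

Compound 3 `Cc1ccc(OCC(=O)N(Cc2cccs2)c2c[nH]nc2C)cc1` now moves in the opposite direction on that same nitrogen: 3-methyl-1H-pyrazol-4-yl in place of oxetan-3-yl on an amide-type nitrogen. The entering group is again a five-membered aromatic pyrazole ring, but it differs from the group of compound 1 in that the methyl sits on ring carbon and the ring carries a hydrogen-bond donor. Going by the values given here, the step from compound 1 to compound 2 is the only evidence that bears on this change, and it points to a return toward a higher number when a pyrazole replaces oxetan-3-yl. Among the compounds with values here, a step of about that size in the upward direction is therefore expected, a 2.2-fold higher number from compound 2 to compound 3 (0.34 log units; beyond the scatter), with wide uncertainty since the methyl position and the donor have no measured precedent. Compound 3 is estimated to give 50000 nM in this assay, within a range of 15000 nM to 150000 nM.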

Compound 3, half-maximal effective concentration: 0.4 nM
Beside the measured number, compound 3's estimate is 130000-fold (5.10 log units) above it; measured number below the stated range.
By their numbers in this assay, from the lowest: compound 3; then compound 2; then compound 1.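

The group on this amide-type nitrogen matters far more than the first step suggested: in this assay, the change from oxetan-3-yl to 3-methyl-1H-pyrazol-4-yl gives a 58000-fold lower number from compound 2 to compound 3 (4.76 log units; beyond the scatter), which dwarfs the modest earlier difference between compound 1 and compound 2. The more telling comparison is a 160000-fold lower number from compound 1 to compound 3 (5.20 log units; beyond the scatter), since both compounds carry a methyl-substituted pyrazole, so having a pyrazole ring at this position is not enough to reach a low number, and compound 1, with the other pyrazole, has the highest number of the three. Small details of the ring therefore count here, namely where the methyl sits and the hydrogen-bond donor of 3-methyl-1H-pyrazol-4-yl, though nothing available explains why this change has such a large effect.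

Those two details change together between compound 1 and compound 3, so the compounds shown cannot tell which of them, or whether both together, accounts for the step. Also open, on these data alone, is how the number would respond to an unsubstituted 1H-pyrazol-4-yl ring, or to an ethyl group in place of the methyl on the ring of compound 3.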